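Working notes: one aryl exchange carried onto a second core

The compounds below may be only part of what the source reports. "The series", "measured", "known", "first", "only" and "open" are said of these compounds alone.

Compound 1 `Cc1ccccc1-n1cc(-c2ccc(/C=C3\C(=O)Nc4ccccc43)cc2)nn1` in an ADME assay on HUVEC cells (Homo sapiens) for inhibition, read by CCK-8 assay, with a stated time of 24 h, in the presence of a further agent that is not named here (on this read-out lower numbers stand for stronger inhibition and higher numbers for weaker inhibition), gives 14700 nM. Compound 2 `O=C1Nc2ccccc2/C1=C/c1ccc(-c2cn(-c3ccc(Cl)cc3)nn2)cc1` differs from it by 4-chlorophenyl in place of 2-methylphenyl on an aromatic nitrogen; in this assay compound 2 gives 18200 nM, and the measured step for this change is a 1.2-fold higher number from compound 1 to compound 2 (0.09 log units; within the scatter). Compound 3 `Cc1ccccc1-n1cc(-c2ccc(C=C3C(=O)Nc4ccc(F)cc43)cc2)nn1` rests on a different core; the difference between the two cores is not broken down here. In this assay compound 3 gives 8630 nM, which against compound 1 lies within the scatter and against compound 2 is a lower number by a margin beyond the scatter.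

Compound 4 `O=C1Nc2ccc(F)cc2C1=Cc1ccc(-c2cn(-c3ccc(Cl)cc3)nn2)cc1` has not been measured. It stands to compound 3 as compound 2 stands to compound 1: 4-chlorophenyl in place of 2-methylphenyl on an aromatic nitrogen, with the place described in the same words, so this is the same change made a second time, here on the core of compound 3. Among the compounds with values here, the step expected from this change is a 1.2-fold higher number from compound 3 to compound 4 (0.09 log units; within the scatter), resting on the single measured instance a 1.2-fold higher number from compound 1 to compound 2 (0.09 log units; within the scatter). In this assay compound 4 is therefore estimated to give 10700 nM, with a range from 5500 nM to 21000 nM.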

Compound 4, half-maximal inhibitory concentration: 19600 nM
Beside the measured number, compound 4's estimate is 1.8-fold (0.26 log units) below it, within the range that was stated.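

On the core of compound 3, 4-chlorophenyl in place of 2-methylphenyl gives a 2.3-fold higher number from compound 3 to compound 4 (0.36 log units; beyond the scatter), a step that the printed scatter does not cover, unlike the step on the core of compound 1. Even so, the two instances in this assay cannot be told apart, since the gap between them is no larger than two such steps would show by scatter alone: the same change on two cores in this assay, a 1.2-fold higher number (0.09 log units; within the scatter) from compound 1 to compound 2 and a 2.3-fold higher number (0.36 log units; beyond the scatter) from compound 3 to compound 4, 1.8-fold (0.26 log units) apart, within the scatter of two such steps. The change can therefore be carried between these two cores as a single modest step, but two pairs do not prove that its size is the same on both cores or predict its size on any further core.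

Still open, from the compounds shown here alone, is how this assay responds when the aromatic nitrogen carries an aryl ring bearing an amine or a carboxylic acid instead of the chlorine or methyl group. Also open, going by these compounds, is whether a longer alkyl chain on that nitrogen could take the place of the aryl ring on either core.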